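The compounds below may be only part of what the source reports. "The series", "measured", "known", "first", "only" and "open" are said of these compounds alone.

In a functional assay on PC-3 cells (Homo sapiens) for antiproliferative activity, read by MTT assay, tested at 5 uM (a lower number here means a weaker effect, a higher number a stronger effect of the compound at the concentration tested), compound 3 `COc1cc(C(=O)N/N=C/c2ccc(F)cc2)cc(OC)c1OC` gives 82.8%, the highest of the three numbers measured. Compound 2 `COc1cc(C(=O)N/N=C/c2ccccc2C(F)(F)F)cc(OC)c1OC` gives 52.9% in this assay, and compound 1 `COc1cc(C(=O)N/N=C/c2ccc(F)c(F)c2)cc(OC)c1OC` gives 43.7%. For the measured compounds named here, the only single-place step among the measured compounds is a number 39.1 percentage points higher from compound 1 to compound 3 (beyond the scatter), a large change for hydrogen in place of fluoro on an aromatic carbon. Compound 4 `COc1cc(C(=O)N/N=C/c2ccccc2F)cc(OC)c1OC` has not yet been measured. It differs from compound 3 in one place: 2-fluorophenyl in place of 4-fluorophenyl on a carbon with a double bond to nitrogen. Going by the values given here, no measured step moves a fluoro from one ring position to another, so the measured step bears on the change only indirectly, through showing that the ring substitution pattern moves the number strongly. Compound 2, the other compound whose ring differs from that of compound 3, stands well below it. Compound 4 is therefore expected to show a weaker effect, an estimated step of a number 22.8 percentage points lower from compound 3 to compound 4 (beyond the scatter). The estimate for compound 4 is 60%, with a range from 35% to 85%.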

Compound 4, a percentage reported as inhibition, at one concentration (the size of the read-out at that concentration, not a potency): 81.8%
For compound 4 the middle estimate is 21.8 percentage points below the measured one; the range from low to high includes it.
By their numbers in this assay, from the lowest: compounds 1 and 2 (each within the scatter of the next); then compounds 4 and 3 (each within the scatter of the next).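

In this assay, for the compounds shown here, the change to 2-fluorophenyl in place of 4-fluorophenyl on the carbon with a double bond to nitrogen gives a number 1 percentage points lower from compound 3 to compound 4 (within the scatter) and so shows that this single fluoro can be moved between these two ring positions without a change beyond the scatter, which the earlier compounds could not show. The larger differences lie elsewhere: fluoro in place of trifluoromethyl gives a number 28.9 percentage points higher from compound 2 to compound 4 (beyond the scatter) and 2-fluorophenyl in place of 3,4-difluorophenyl gives a number 38.1 percentage points higher from compound 1 to compound 4 (beyond the scatter) so both rings with a single fluoro stand clear of these two rings with more fluorine. No measurement here offers an explanation for these differences. The compounds shown leave open whether 3-fluorophenyl would match the two rings with a single fluoro, and whether a ring bearing chloro, an amine or a carboxylic acid would do so.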